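A Larger Hydroxy-Bearing Ring on the Shared Core

The source may report more compounds than this note shows. Statements on the series, on what has been measured and on what is new or still open speak of the compounds shown alone.

Of the compounds shown here, two with a shared core have been measured in an assay on isolated protein for inhibition of protein kinase C theta type (Homo sapiens), read by TR-FRET, with a stated time of 2 h; a higher number here means a weaker inhibitor, a lower number a stronger inhibitor. Compound 1 `N#Cc1cnc(NCc2cnccc2C(F)(F)F)cc1NC[C@H]1C[C@@H](O)C1` gives 300 nM in this assay, which is the highest of the two numbers. Compound 2 `N#Cc1cnc(NCc2cncnc2OCC(F)F)cc1N[C@H]1CC[C@@H](O)CC1` differs from compound 1 in several positions. In this assay compound 2 gives 90 nM, and the gap between compound 1 and compound 2 lies beyond the usual scatter.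

Compound 3 `CC1(C)C[C@@H](Nc2cc(NCc3cnccc3C(F)(F)F)ncc2C#N)CC[C@@H]1O` has not yet been measured. It is reached from compound 1 by a single change: 4-hydroxy-3,3-dimethylcyclohexyl in place of (3-hydroxycyclobutyl)methyl on a nitrogen on an aromatic ring. The entering group is larger than the leaving one, and the ring now sits directly on the nitrogen rather than through a single carbon.

Because compound 2 gives 90 nM with a hydroxy-bearing six-membered ring sitting directly on the same nitrogen, a step toward a lower number is expected from compound 1 to compound 3, and the expected step is a 2.7-fold lower number from compound 1 to compound 3 (0.44 log units; beyond the scatter). Compound 3 is estimated to give 110 nM in this assay, with a range from 35 nM to 350 nM.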

Compound 3, half-maximal inhibitory concentration: 120 nM
Estimate against measurement, compound 3: 1.1-fold (0.04 log units) below, within the range that was stated.
By their numbers in this assay, from the lowest: compounds 2 and 3 (each within the scatter of the next); then compound 1.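

In this assay, going by these compounds alone, the one change on the nitrogen gives a 2.5-fold lower number from compound 1 to compound 3 (0.40 log units; beyond the scatter), a modest step, and this is the first comparison on the shared core in which only this group differs. It shows that, on a nitrogen on an aromatic ring, (3-hydroxycyclobutyl)methyl can be replaced by the larger 4-hydroxy-3,3-dimethylcyclohexyl, with 9 heavy atoms in place of 6, and that the number falls rather than rises. The change alters several things at once: the ring size, the single carbon that linked the ring to the nitrogen and the two methyl groups, and nothing measured here gives a reason for the step.

Going by these compounds, it remains open which of those parts carries the step, a question that 4-hydroxycyclohexyl on the core of compound 1 would bear on directly. Also open, on these data alone, is how this position responds when the hydroxy group on the ring is replaced by an amine or a carboxylic acid.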